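Ethyl for Trifluoromethyl on a Weakly Active Quinazoline Pair

This account rests on a few compounds, and the source may have more. Where it says the series, first, only, none or still open, it means among the compounds named here.

Compound 1 `C=CC(=O)Nc1cccc(NC(=O)CSc2nc(Nc3ccccc3Cl)c3ccccc3n2)c1` — in a functional assay on NCI-H1975 cells (Homo sapiens) for inhibition, read by MTT assay, with a stated time of 72 h (a higher number here means a weaker inhibitor, a lower number a stronger inhibitor), compound 1 gives 10000 nM.
Compound 2 `C=CC(=O)Nc1cccc(NC(=O)CSc2nc(Nc3ccc(C(F)(F)F)cc3)c3ccccc3n2)c1` — in this assay compound 2 gives 12900 nM.

Among the compounds with values here, compound 2 carries the higher of the two numbers so far, but its only neighbour, compound 1, sits within the usual scatter: a 1.3-fold higher number from compound 1 to compound 2 (0.11 log units; within the scatter). Compound 3 `C=CC(=O)Nc1cccc(NC(=O)CSc2nc(Nc3ccc(CC)cc3)c3ccccc3n2)c1` differs from compound 2 in one place, (ethyl in place of trifluoromethyl on an aromatic carbon). Within the data shown here, the single measured step bears on this change only loosely: it exchanged one aryl group on the same nitrogen for another and moved the number by an amount within the scatter. Among the measured compounds shown here, nothing measured here involves an ethyl group, so there is no direct precedent for the new substituent. On that basis no shift beyond the scatter is expected in this assay, and the step from compound 2 to compound 3 is estimated as a 1.3-fold lower number from compound 2 to compound 3 (0.11 log units; within the scatter). Compound 3 is therefore expected at 10000 nM, with a range from 4000 nM to 30000 nM.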

Compound 3, half-maximal inhibitory concentration: 8270 nM
The estimate for compound 3 lay 1.2-fold (0.08 log units) above the measured number; the measured number falls inside the stated range.
By their numbers in this assay, from the lowest: compounds 3, 1 and 2 (each within the scatter of the next).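

In this assay, ethyl in place of trifluoromethyl on the aromatic carbon para to a large group gives a 1.6-fold lower number from compound 2 to compound 3 (0.19 log units; within the scatter) and so brings no shift that stands clear of the scatter. This holds even though ethyl has fewer heavy atoms and no fluorine. Set against compound 1, the 4-ethylphenyl group in place of 2-chlorophenyl on the same nitrogen gives a 1.2-fold lower number from compound 1 to compound 3 (0.08 log units; within the scatter) and leaves all three compounds within the scatter of one another, with no measurement available here to explain why the numbers stay so close.

The compounds shown leave open whether an amine, a carboxylic acid or a longer chain at this position would move the number beyond the scatter in this assay at all. They also leave open whether a change elsewhere on the shared core would do so.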